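Ethyl Replacing Hydrogen on the Oxygen: Expected Response

The source may report more compounds than this note shows. Statements on the series, on what has been measured and on what is new or still open speak of the compounds shown alone.

Of the compounds shown here, three have so far been measured in a functional assay on HEK293 cells with D(4) dopamine receptor (Homo sapiens) as the target, read by FLIPR; a higher number here means a larger maximal response, a lower number a smaller maximal response. Compound 1 `O/N=C(\CCN1CCN(c2ccccn2)CC1)c1ccccc1` gives 70%. Compound 2 `O/N=C(\CCN1CCN(c2ncccn2)CC1)c1ccccc1` gives 49%, and compound 3 `O/N=C(/CCN1CCN(c2ncccn2)CC1)c1ccccc1` gives 52%. Compound 2 stands lowest of the three, though its gap to compound 3 lies within the scatter. Changing the ring on the amine nitrogen gave a number 21 percentage points lower from compound 1 to compound 2 (beyond the scatter); the comparison of compound 2 with compound 3 gave a number 3 percentage points higher from compound 2 to compound 3 (within the scatter), which rests on (the fact that compounds 2 and 3 differ only in the configuration as drawn). Compound 4 `CCO/N=C(\CCN1CCN(c2ncccn2)CC1)c1ccccc1` differs from compound 2 by ethyl in place of hydrogen on an oxygen. Neither measured step touched this oxygen, so the expected change is a number 1 percentage points higher from compound 2 to compound 4 (within the scatter), nothing beyond the scatter. Compound 4 is therefore estimated at 50%, with a range from 30% to 70%.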

Compound 4, largest response reached (reported as efficacy), in percent of the reference or control that the assay uses: 26%
Compound 4: the middle estimate sits 24 percentage points above what was measured; the measured number lies below the stated range.
By their numbers in this assay, from the lowest: compound 4; then compounds 2 and 3 (each within the scatter of the next); then compound 1.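

Among the compounds shown here, the oxygen on the double-bonded nitrogen turns out to matter in this assay: going from hydroxy to ethoxy gives a number 23 percentage points lower from compound 2 to compound 4 (beyond the scatter) and so marks the first change at this position that moves the maximal response beyond the scatter. Ethyl on this oxygen is therefore not a neutral swap in this series. Nothing available explains why the response falls. Open, as far as these compounds go, is whether methyl or a longer chain such as propyl on this oxygen would behave like ethyl. Also open, from the compounds shown here alone, is whether ethyl would have the same effect on compound 1 or compound 3.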